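The source may hold more compounds than are shown below. What is called first, only, known or untested is meant among the compounds shown, and "the series" means these compounds.

Two compounds share one core and differ only in the group attached to an aromatic carbon of the six-membered ring that carries two nitrogen atoms. Compound 1, `CCCCCCc1cnc(-c2nn(Cc3ccccc3F)c3ncccc23)nc1N`, carries a hexyl chain there, and in a functional assay (aorta) with Oryctolagus cuniculus as the target (on this read-out higher numbers stand for weaker inhibition and lower numbers for stronger inhibition), compound 1 gives 1040000 nM. Compound 2, `Nc1nc(-c2nn(Cc3ccccc3F)c3ncccc23)ncc1C1=CCCC1`, carries a cyclopent-1-en-1-yl group in the same place, and in this assay compound 2 gives 836000 nM. The step of a 1.2-fold lower number from compound 1 to compound 2 (0.09 log units; within the scatter) lies within the usual scatter, so the two values show no real difference; compound 2 stands next to compound 1 with nothing separating them beyond that scatter.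

Compound 3, `N#Cc1cnc(-c2nn(Cc3ccccc3F)c3ncccc23)nc1N`, has not yet been measured. It differs from compound 2 by cyano in place of cyclopent-1-en-1-yl on an aromatic carbon. Among the compounds with values here, the only measured step, a 1.2-fold lower number from compound 1 to compound 2 (0.09 log units; within the scatter), swapped one all-carbon group for another and changed nothing beyond the scatter; a cyano group is a different kind of substituent, and no measured step shows what such a change does here. Compound 3 is therefore expected to give a value close to that of compound 2, with the step of a 1.2-fold higher number from compound 2 to compound 3 (0.08 log units; within the scatter) as the estimate. For compound 3 the estimated value in this assay is 1000000 nM, with a range from 300000 nM to 3000000 nM.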

Compound 3, half-maximal inhibitory concentration: 391000 nM
Compound 3: middle estimate off by 2.6-fold (0.41 log units), on the high side; the measured number falls inside the stated range.
By their numbers in this assay, from the lowest: compound 3; then compounds 2 and 1 (each within the scatter of the next).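

Swapping one all-carbon group for another at this position, ortho to an amino group, left no readable difference, but cyano gives a 2.1-fold lower number from compound 2 to compound 3 (0.33 log units; beyond the scatter) and a 2.7-fold lower number from compound 1 to compound 3 (0.42 log units; beyond the scatter) in this assay so the position does respond to what it carries, if only modestly. Both steps lie beyond the scatter, which makes compound 3 the strongest inhibitor of the three, while compounds 1 and 2 remain indistinguishable from each other. The data offer no measured explanation for this shift.

Cyano differs from cyclopent-1-en-1-yl in several ways at once, with fewer heavy atoms, no ring, a nitrogen and a hydrogen-bond acceptor, so this single comparison cannot show which of these differences matters. A small group without nitrogen, such as methyl or a chlorine atom, and a nitrogen-bearing group of another kind, such as a primary amide or a carboxylic acid, would be needed to tell whether the lower number goes with small size or with the nitrogen.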